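A few compounds are considered here, and "the series" means these few. Any claim that something is new, unique, unknown or untested is made for them only; others in the source may bear on it.

For the measured compounds named here, compound 2 `COc1ccc(C(=O)/C=C/c2cc(-c3cc(OC)c(OC)c(OC)c3)n[nH]2)cc1` holds the lowest of the two numbers measured so far, though the gap to compound 1 is within the scatter: in a functional assay on NCI/ADR-RES cells (Homo sapiens) for inhibition, read by sulforhodamine B assay, with a stated time of 48 h (on this read-out lower numbers stand for stronger inhibition of growth and higher numbers for weaker inhibition of growth), compound 2 gives 9850 nM. Compound 1 `COc1ccc(C(=O)/C=C/c2cc(-c3cc(OC)c(OC)c(OC)c3)n[nH]2)cc1OC` gives 15700 nM in this assay. Compound 3 `COc1cc(-c2cc(/C=C/C(=O)c3ccc(F)c(F)c3)[nH]n2)cc(OC)c1OC` differs from compound 2 by 3,4-difluorophenyl in place of 4-methoxyphenyl on a carbonyl carbon. Going by the values given here, the only measured step, a 1.6-fold lower number from compound 1 to compound 2 (0.20 log units; within the scatter), stayed within the scatter, and nothing measured trades one aryl group for another, so the expected step is a 1.1-fold lower number from compound 2 to compound 3 (0.04 log units; within the scatter), no more than the scatter. Compound 3 is therefore estimated at 9000 nM, with a range from 3000 nM to 30000 nM.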

Compound 3, concentration for total growth inhibition: 50500 nM
For compound 3 the middle estimate is 5.6-fold (0.75 log units) below the measured one; the whole stated range lies below it.
By their numbers in this assay, from the lowest: compounds 2 and 1 (each within the scatter of the next); then compound 3.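

On the carbonyl carbon, the choice of aryl group does matter in this assay: the change to 3,4-difluorophenyl brings two modest steps, a 5.1-fold higher number from compound 2 to compound 3 (0.71 log units; beyond the scatter) and a 3.2-fold higher number from compound 1 to compound 3 (0.51 log units; beyond the scatter). Removing one methoxy had stayed within the scatter, so this position accepts that smaller change but responds once fluorines replace the methoxy groups. Nothing available explains this shift. Still open, on these data alone, is whether a 4-hydroxyphenyl or 4-aminophenyl group here would stay close to compound 2, or whether plain phenyl would sit nearer compound 3.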